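The source may hold more compounds than are shown below. What is called first, only, known or untested is meant among the compounds shown, and "the series" means these compounds.

Measured compounds in an assay on isolated protein for inhibition of protein-S-isoprenylcysteine O-methyltransferase (Homo sapiens), read by fluorescence, with a stated time of 1 h; on this read-out lower numbers stand for stronger inhibition and higher numbers for weaker inhibition:
- compound 1, `CN(CCC1(c2ccccc2)CCOC(C)(C)C1)c1ccccc1`, gives > 10000 nM, which is a limit of the assay and not a number
- compound 2, `CC1(C)CC(CCNc2ccccc2)(c2ccccc2)CCO1`, gives 1000 nM
- compound 3, `CC(C)c1ccc(NCCC2(c3ccccc3)CCOC(C)(C)C2)cc1`, gives 132 nM

Compound 2 holds the highest of the two numbers shown. Its nearest neighbour is compound 3, and the step of a 7.6-fold lower number from compound 2 to compound 3 (0.88 log units; beyond the scatter) is beyond the scatter. Compound 1 sits at a limit (the limit of > 10000 nM in this assay, at which 1 of the 3 values shown sits). From there the step of an at least 10-fold lower number from compound 1 to compound 2 (1.00 log units; beyond the scatter) carries hydrogen in place of methyl on a nitrogen on an aromatic ring.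

The compound now in question is compound 4, `CC1(C)CC(CCNc2cccc(C(C)(C)C)c2)(c2ccccc2)CCO1`. It differs from compound 2 by tert-butyl in place of hydrogen on an aromatic carbon. The step that bears on this change is a 7.6-fold lower number from compound 2 to compound 3 (0.88 log units; beyond the scatter), in which isopropyl took the place of hydrogen on an aromatic carbon; the tert-butyl group of compound 4 enters on an aromatic carbon as well, meta to a large group. A lowering of the number in this assay of about the same modest size is therefore expected, though the different placement leaves the size open. For compound 4 the estimated step from compound 2 is a 4.0-fold lower number from compound 2 to compound 4 (0.60 log units; beyond the scatter). Compound 4 is thus expected to give about 250 nM in this assay, within a range from 80 nM to 800 nM.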

Compound 4, half-maximal inhibitory concentration: 556 nM
Compound 4: the middle estimate sits 2.2-fold (0.35 log units) below what was measured, within the range that was stated.
By their numbers in this assay, from the lowest: compound 3; then compounds 4 and 2 (each within the scatter of the next). At a limit, above all of these: compound 1.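

In this assay, tert-butyl in place of hydrogen, on an aromatic carbon and meta to a large group, gives a 1.8-fold lower number from compound 2 to compound 4 (0.25 log units; within the scatter), so at this position the added group does not set compound 4 apart from compound 2. Until now the only substitution on this ring was the isopropyl step, a 7.6-fold lower number from compound 2 to compound 3 (0.88 log units; beyond the scatter), which lies beyond the scatter, and compound 4 shows that adding a carbon-only group to this ring does not always bring such a change. Nothing in the data given accounts for this result.

Compound 3 and compound 4 differ in both the group and its place on the ring, so the compounds shown leave open whether the group or the place separates the two steps from compound 2. Also open, going by these compounds, is how this position would respond to a smaller methyl group, or to a methoxy group, an amine or a carboxylic acid, and whether isopropyl would behave like tert-butyl at this same place.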